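Benzyl in Place of Tert-butyl on Carbamates at the Assay Limit

The source may hold more compounds than are shown below. What is called first, only, known or untested is meant among the compounds shown, and "the series" means these compounds.

Compound 1, `O=C(OCc1ccccc1)N1CCN(C(=S)SCc2cn(Cc3ccc(Cl)cc3)nn2)CC1`: in a functional assay on PC-3 cells (Homo sapiens) for inhibition, read by MTT assay, with a stated time of 72 h (on this read-out lower numbers stand for stronger inhibition and higher numbers for weaker inhibition), compound 1 gives > 128000 nM, a limit of the assay.
Compound 2, `COc1ccc(Cn2cc(CSC(=S)N3CCN(C(=O)OCc4ccccc4)CC3)nn2)cc1`: compound 2 gives > 128000 nM, a limit of the assay.
Compound 3, `CC(C)(C)OC(=O)N1CCN(C(=S)SCc2cn(Cc3ccc(Cl)c(Cl)c3)nn2)CC1`: compound 3 gives > 128000 nM, a limit of the assay.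

Compound 3 thus stands at the limit alongside the other two compounds (the limit of > 128000 nM in this assay, at which 3 of the 3 values shown sit). The step from compound 1 to compound 2, a step that the two limits leave unreadable from compound 1 to compound 2, cannot be read from two limits. Compound 4, `O=C(OCc1ccccc1)N1CCN(C(=S)SCc2cn(Cc3ccc(Cl)c(Cl)c3)nn2)CC1`, differs from compound 3 by benzyl in place of tert-butyl on an oxygen next to a carbonyl group. For the measured compounds named here, no measured step directly covers this change, yet compounds 1 and 2 already carry the benzyloxycarbonyl group and both sit at the limit. This change is therefore expected to amount to a step that the limit leaves unreadable from compound 3 to compound 4, nothing beyond the scatter. Compound 4 is expected to give 200000 nM, within 64000 nM to 1000000 nM.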

Compound 4, half-maximal inhibitory concentration: > 128000 nM
Compound 4 gave a limit, no number; the forecaster's own chance of this, stated with the estimate: 90%; the middle value lies beyond the limit too.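

Compound 4 gives > 128000 nM, a limit and not a number, so its steps from compound 1, compound 2 and compound 3 cannot be read. The compounds shown leave open whether any of these changes alters the result in this assay: the limit of > 128000 nM in this assay, at which 4 of the 4 values shown sit.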